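Nitro in Place of Hydrogen on the Benzoyloxy Group

The source may report more compounds than this note shows. Statements on the series, on what has been measured and on what is new or still open speak of the compounds shown alone.

Measured compounds:
compound 1 `CC1=CC[C@H]2[C@H](CC[C@]2(C)O)C(C)(C)[C@@H]1CC[C@H]1[C@]2(C)CC[C@H](OC(=O)c3ccccc3)C(C)(C)O[C@H]2CC[C@@]1(C)O` — 16100 nM
compound 2 `CC1=CC[C@H]2[C@@H]1CC=C(C)[C@@H](CC[C@H]1[C@]3(C)CC[C@H](OC(=O)CCC(=O)O)C(C)(C)O[C@H]3CC[C@@]1(C)O)C2(C)C` — 29600 nM
compound 3 `CC1=CC[C@H]2[C@H](CC[C@]2(C)O)C(C)(C)[C@@H]1CC[C@H]1[C@]2(C)CC/C(=N/OCc3ccccc3)C(C)(C)O[C@H]2CC[C@@]1(C)O` — 38200 nM

In a functional assay on MDA-MB-231 cells (Homo sapiens) for antiproliferative activity, read by MTT assay, with a stated time of 72 h (a higher number here means a weaker inhibitor, a lower number a stronger inhibitor), compound 1 gives 16100 nM, the lowest of the three numbers. Compound 2 lies within the scatter of compound 1, so no order can be claimed between them; compound 3 lies beyond the scatter, with the higher number. Compound 4 `CC1=CC[C@H]2[C@H](CC[C@]2(C)O)C(C)(C)[C@@H]1CC[C@H]1[C@]2(C)CC[C@H](OC(=O)c3ccccc3[N+](=O)[O-])C(C)(C)O[C@H]2CC[C@@]1(C)O` differs from compound 1 by nitro in place of hydrogen on an aromatic carbon. Going by the values given here, no pair of measured compounds that differ in one place is available, so the size of this change cannot be read from the data. The account therefore expects a step from compound 1 to compound 4 of a 1.0-fold lower number from compound 1 to compound 4 (0.00 log units; within the scatter), no further than the scatter. Compound 4 is expected to give 16000 nM, within a range from 7000 nM to 40000 nM.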

Compound 4, half-maximal inhibitory concentration: 38700 nM
Compound 4: middle estimate off by 2.4-fold (0.38 log units), on the low side; the measured number falls inside the stated range.
By their numbers in this assay, from the lowest: compounds 1, 2, 3 and 4 (each within the scatter of the next, the first and the last beyond it).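

In this assay, nitro in place of hydrogen on an aromatic carbon, ortho to a large group, gives a 2.4-fold higher number from compound 1 to compound 4 (0.38 log units; beyond the scatter). This first step between compounds that differ in one place is modest, yet it shows that this position on the benzoyloxy group does not accept the change without a shift in the number. Nothing measured here accounts for the step.

From the compounds shown here alone, whether an amine or a methoxy group at the same place would give a step in the same direction stays open. So does whether nitro elsewhere on the six-membered aromatic ring would give a step of this size.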